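This account rests on a few compounds, and the source may have more. Where it says the series, first, only, none or still open, it means among the compounds named here.

Of the compounds shown here, three have been tested in an assay on isolated protein for displacement of a labelled ligand from metabotropic glutamate receptor 5 (Homo sapiens), with a stated time of 60 min, tested at 1 uM; on this read-out higher numbers stand for more inhibition at the one concentration tested (going by the name of the read-out) and lower numbers for less inhibition. Compound 2 `Cc1ccc2ncc(S(=O)(=O)c3ccc(F)cc3)c(N3CCC(C)CC3)c2c1` gives 90%, while compound 1 `COc1ccc(S(=O)(=O)c2cnc3ccc(C)cc3c2N2CCC(C)CC2)cc1` gives 62%. These two differ in one place, (methoxy in place of fluoro on an aromatic carbon), and that change gave a number 28 percentage points lower from compound 2 to compound 1 (beyond the scatter). Compound 3 `CC1CCN(c2c(S(=O)(=O)c3ccc(F)c(Cl)c3)cnc3cc(Cl)ccc23)CC1` gives 94% in this assay; its number and that of compound 2 lie within the scatter of each other, and the difference between the two cores is not broken down here.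

Compound 4 `COc1ccc(S(=O)(=O)c2cnc3cc(Cl)ccc3c2N2CCC(C)CC2)cc1Cl` has not yet been measured in this assay. It differs from compound 3 by methoxy in place of fluoro on an aromatic carbon. The surroundings are not identical: in compound 4 the entering group sits ortho to a chloro group, which is not so in compound 1, so this is the same kind of change rather than the same change. The expected step is a number 28 percentage points lower from compound 3 to compound 4 (beyond the scatter), resting on the earlier a number 28 percentage points lower from compound 2 to compound 1 (beyond the scatter). On that basis compound 4 is estimated at 66%, expected to fall between 50% and 82%.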

Compound 4, a percentage reported as inhibition, at one concentration (the size of the read-out at that concentration, not a potency): 93%
Estimate against measurement, compound 4: 27 percentage points below, and the stated range ends below it.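

In this assay, methoxy in place of fluoro gives a number 1 percentage points lower from compound 3 to compound 4 (within the scatter), so the drop seen with the core of compound 1 does not carry over to the core of compound 3. The two results differ, so in this series the size of this change depends on its surroundings: the same change on two cores in this assay, a number 28 percentage points lower (beyond the scatter) from compound 2 to compound 1 and a number 1 percentage points lower (within the scatter) from compound 3 to compound 4, 27 percentage points apart, beyond the scatter of two such steps What this does not show is which difference between the pairs matters, since compound 4 has its methoxy ortho to a chloro group and its core also differs from that of compound 1, and a single pair of each kind cannot separate these; the read-out also covers one concentration only, so it tells nothing about the effect of compound 3 and compound 4 at any other concentration.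

The compounds shown leave open what happens when only one of those features varies, for example with a 3-chloro-4-fluorophenyl group on the core of compound 2. They also leave open how an ethoxy group, an amine or a carboxylic acid would read at that same place.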